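The compounds below may be only part of what the source reports. "The series", "measured", "known", "first", "only" and "open" are said of these compounds alone.

Of the compounds shown here, two have been measured so far in an assay on HEK-293T cells for antagonist activity at vitamin D3 receptor (Homo sapiens), read by a luciferase reporter, with a stated time of 24 h; a higher number here means a weaker inhibitor, a lower number a stronger inhibitor. Compound 1 `CCC(CC)n1c(-c2ccc(OCc3c(-c4c(Cl)cccc4Cl)noc3C(C)C)cc2)nc2ccc(C(=O)O)cc21` gives 5690 nM, and compound 2 `CC(C)c1onc(-c2c(Cl)cccc2Cl)c1COc1ccc(-c2nc3ccc(C(=O)O)cc3n2CC(C)(C)C)cc1` gives 861 nM. Going by the values given here, the single step between them, a 6.6-fold lower number from compound 1 to compound 2 (0.82 log units; beyond the scatter), is the only comparison available. On these numbers compound 2 stands at the lower of the two values, with compound 1 as its nearest neighbour, and nothing else places it further.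

Compound 3 `CCn1c(-c2ccc(OCc3c(-c4c(Cl)cccc4Cl)noc3C(C)C)cc2)nc2ccc(C(=O)O)cc21` has not yet been measured. It differs from compound 2 by methyl in place of tert-butyl on a saturated chain carbon bound to an aromatic nitrogen. Among the compounds with values here, the one measured step that bears on this change is a 6.6-fold lower number from compound 1 to compound 2 (0.82 log units; beyond the scatter), which also alters the group on the aromatic nitrogen, though differently: there pentan-3-yl gave way to neopentyl, here neopentyl is cut back to ethyl. That step is modest and gives no direct reading of an ethyl at this position. The expected step is therefore a 2.9-fold higher number from compound 2 to compound 3 (0.46 log units; beyond the scatter), most likely toward a higher number, with wide uncertainty in either direction. Compound 3 is estimated to give 2500 nM, within a range of 600 nM to 10000 nM.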

Compound 3, half-maximal inhibitory concentration: 5760 nM
Estimate against measurement, compound 3: 2.3-fold (0.36 log units) below, within the range that was stated.
By their numbers in this assay, from the lowest: compound 2; then compounds 1 and 3 (each within the scatter of the next).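

In this assay, the move from neopentyl to ethyl gives a 6.7-fold higher number from compound 2 to compound 3 (0.83 log units; beyond the scatter) and so shows that the lower number of compound 2 does not survive this cut; the earlier pair showed only that neopentyl outdid pentan-3-yl, with no reading of a group as small as ethyl. The comparison of the other two, a 1.0-fold higher number from compound 1 to compound 3 (0.01 log units; within the scatter), places ethyl and pentan-3-yl level within the scatter, so among these three groups on an aromatic nitrogen neopentyl alone stands apart, and the numbers do not run in a simple order from the smallest group to the largest. Nothing given here explains why neopentyl stands apart from the other two groups.

From the compounds shown here alone, whether the lower number belongs to neopentyl in particular or extends to other groups in that place, such as isobutyl, cyclopropylmethyl or a longer straight chain, remains open. Also open, going by these compounds, is whether the difference between neopentyl and ethyl would persist if the carboxylic acid on the shared core were replaced by an amide or a tetrazole.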